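Chloro to methyl on two rings of a benzimidazole ether series

This account rests on a few compounds, and the source may have more. Where it says the series, first, only, none or still open, it means among the compounds named here.

Three compounds of the series have been run in an ADME assay on Vero cells (Chlorocebus sabaeus) for cytotoxicity, read by luminescence, with a stated time of 2 days; on this read-out higher numbers stand for lower toxicity in this test and lower numbers for higher toxicity in this test. Compound 1 `CCc1nc2ccccc2n1CCCCOc1cccc(C)c1` gives 19 uM, compound 2 `CCc1nc2ccccc2n1CCCCOc1cccc(Cl)c1` gives 22 uM, and compound 3 `CCc1nc2ccc(Cl)cc2n1CCCCOc1ccccc1` gives 25 uM. All three numbers sit within the scatter of one another, so no order among them is claimed.

Compound 1 differs from compound 2 by methyl in place of chloro on an aromatic carbon, and this exchange gave a 1.2-fold lower number from compound 2 to compound 1 (0.06 log units; within the scatter). The cores of compound 3 and compound 2 are built from the same atoms joined differently; that difference between the two cores is not broken down here.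

Compound 4 `CCc1nc2ccc(C)cc2n1CCCCOc1ccccc1` is not yet measured. It differs from compound 3 by methyl in place of chloro on an aromatic carbon. Among the compounds with values here, this is the same kind of change as the one from compound 2 to compound 1, not the same: in compound 1 the methyl sits on a six-membered aromatic ring of carbon only, meta to a large group, whereas in compound 4 it sits on a ring that is part of a fused or bridged system of two rings, meta to a fused ring and para to a fused ring.

In this assay the step expected for this exchange is a 1.2-fold lower number from compound 3 to compound 4 (0.08 log units; within the scatter), because the matched exchange gave a 1.2-fold lower number from compound 2 to compound 1 (0.06 log units; within the scatter). Compound 4 is therefore estimated at 21 uM, with a plausible range from 10 uM to 45 uM.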

Compound 4, half-maximal toxic concentration: 18 uM
Compound 4: middle estimate off by 1.2-fold (0.07 log units), on the high side, and the stated range covers the measured number.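

In this assay, methyl in place of chloro on an aromatic carbon of a six-membered aromatic ring of carbon only, part of a fused or bridged system of two rings, gives a 1.4-fold lower number from compound 3 to compound 4 (0.14 log units; within the scatter). Set beside the earlier exchange on the other ring, the step carries over from one core to the other without a difference that can be told from the scatter: the same change on two cores in this assay, a 1.2-fold lower number (0.06 log units; within the scatter) from compound 2 to compound 1 and a 1.4-fold lower number (0.14 log units; within the scatter) from compound 3 to compound 4, 1.2-fold (0.08 log units) apart, within the scatter of two such steps. Within the data shown here, this does not show that the exchange moves the read-out at all, since each step lies within the scatter on its own; the agreement is between two small steps from only two matched pairs, so it supports no more than the absence of a visible effect of this exchange on these two cores.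

Left open is whether a group other than chloro or methyl on these aromatic carbons, such as an amine or a carboxylic acid, would give a step beyond the scatter in this assay. Also open, on these data alone, is whether the exchange stays as small on compounds carrying a longer chain in place of the ethyl group, or a shorter chain in place of the four-carbon linker.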